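Methoxy to methylpiperazinylmethyl on the triazole side chain

The source may report more compounds than this note shows. Statements on the series, on what has been measured and on what is new or still open speak of the compounds shown alone.

Two measured compounds share the diaryl urea–triazole core. Compound 1 `COCCc1cn(-c2ccc(NC(=O)Nc3ccccc3C)cc2)nn1` is the reference; in an assay on isolated protein for inhibition of ATP-dependent RNA helicase DDX3X (Homo sapiens), read by FRET, with stated times of 30 s and 40 min (a lower number here means a stronger inhibitor, a higher number a weaker inhibitor), compound 1 gives 1000 nM. Compound 2 `CCOC(=O)CCc1cn(-c2ccc(NC(=O)Nc3ccccc3C(F)(F)F)cc2)nn1` carries a trifluoromethyl in place of the methyl on the urea-linked ring and an ethyl ester chain instead of the methoxyethyl; in this assay compound 2 gives 2020 nM. Compound 1 thus stands lowest of the two numbers, with compound 2 showing a higher number that lies beyond the scatter. For the measured compounds named here, the two differ in two places at once, so the pair gives no single-point step.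

Compound 3 `Cc1ccccc1NC(=O)Nc1ccc(-n2cc(CCCN3CCN(C)CC3)nn2)cc1` is the untested member. Relative to compound 1 the change is (4-methylpiperazin-1-yl)methyl in place of methoxy on a saturated chain carbon, two bonds along the chain from an aromatic carbon. Going by the values given here, no measured pair in this small set isolates a change of this kind on the chain, so the expectation rests on compound 1 alone. The expected step is a 1.3-fold lower number from compound 1 to compound 3 (0.10 log units; within the scatter), a change not clearly beyond the scatter in either direction. Compound 3 is therefore estimated at 800 nM, with a range from 250 nM to 2500 nM.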

Compound 3, half-maximal inhibitory concentration: 40100 nM
For compound 3 the middle estimate is 50-fold (1.70 log units) below the measured one, and the stated range ends below it.
By their numbers in this assay, from the lowest: compound 1; then compound 2; then compound 3.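

Working notes on the side chain: this position is not indifferent to what it carries. In this assay, replacing methoxy with (4-methylpiperazin-1-yl)methyl on a saturated chain carbon, two bonds along the chain from an aromatic carbon, gives a 40-fold higher number from compound 1 to compound 3 (1.60 log units; beyond the scatter), with the rest of compound 1 left unchanged. For the compounds shown here, this is the first single-point step, as compound 1 and compound 2 differ in two places at once, and it shows that this change on the chain costs far more than the gap between those two compounds. No measurement at hand says which feature of the entering group accounts for the step.

Still open, from the compounds shown here alone, is whether the step follows the six-membered ring, its nitrogens or the added chain length, and one group replacing the methoxy cannot separate these. A morpholin-4-ylmethyl group, an open-chain amine such as dimethylaminomethyl, a plain longer alkyl chain or a carboxylic acid at the same place on the chain would each test a different part of that question.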